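Cyano in Place of Chloro: Working Notes on Compound 3

The source may hold more compounds than are shown below. What is called first, only, known or untested is meant among the compounds shown, and "the series" means these compounds.

Compound 1 `O=c1ccoc2cc(OCc3cn(Cc4cccc(F)c4)nn3)ccc12` sits at the limit of a functional assay on MDA-MB-231 cells (Homo sapiens) for cytotoxicity, read by MTT assay, with a stated time of 48 h; a lower number here means a stronger inhibitor, a higher number a weaker inhibitor: in this assay compound 1 gives > 100000 nM, a limit rather than a number. Compound 2 `O=c1ccoc2cc(OCc3cn(Cc4cccc(Cl)c4)nn3)ccc12` likewise gives > 100000 nM in this assay, again a limit. The step that the two limits leave unreadable from compound 1 to compound 2 therefore cannot be read, since both values sit at the limit of > 100000 nM in this assay, at which 2 of the 2 values shown sit. Compound 3 `N#Cc1cccc(Cn2cc(COc3ccc4c(=O)ccoc4c3)nn2)c1` differs from compound 2 by cyano in place of chloro on an aromatic carbon. Within the data shown here, no measured step speaks to this change: the single measured step leaves no readable size, so there is nothing to carry forward. With both measured compounds at the limit, the expectation for compound 3 is that it too returns no number; the step that the limit leaves unreadable from compound 2 to compound 3 is therefore expected to be flat within the scatter. Compound 3 is accordingly estimated at 150000 nM, with a range of 50000 nM to 500000 nM, most likely reported only as a limit.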

Compound 3, half-maximal inhibitory concentration: > 100000 nM
Compound 3 ended at the assay's limit; the forecaster's own chance of this, stated with the estimate: 85%; the middle value lies beyond the limit too.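

The steps from compound 1 and compound 2 to compound 3 cannot be read, because all three compounds sit at one limit rather than at numbers: the limit of > 100000 nM in this assay, at which 3 of the 3 values shown sit.

In this assay the compounds shown leave open whether fluoro, chloro and cyano differ at all.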